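The source may hold more compounds than are shown below. What is called first, only, known or untested is meant among the compounds shown, and "the series" means these compounds.

Compound 3 `COc1c(/C=C2/C(=O)Nc3ccc(Cl)cc32)c2ccccc2n1-c1ccccc1` gives 24000 nM in a functional assay on cells (Cancer cell lines, Homo sapiens) for cytotoxicity, with a stated time of 48 h (a higher number here means a weaker inhibitor of growth, a lower number a stronger inhibitor of growth), the highest number among the three measured compounds. Compound 1 `COc1cc2c(/C=C3/C(=O)Nc4ccc(Cl)cc43)c(Cl)n(Cc3cc(OC)c(OC)c(OC)c3)c2cc1C` gives 13800 nM, within the scatter of compound 3, while compound 2 `COc1c(/C=C2/C(=O)Nc3ccccc32)c2ccccc2n1-c1ccccc1` gives 4070 nM. Among the measured compounds shown here, the single step separating those two is a 5.9-fold higher number from compound 2 to compound 3 (0.77 log units; beyond the scatter), brought about by chloro in place of hydrogen on an aromatic carbon. Compound 4 `COc1ccc2c(c1)/C(=C\c1c(OC)n(-c3ccccc3)c3ccccc13)C(=O)N2` differs from compound 3 by methoxy in place of chloro on an aromatic carbon. For the measured compounds named here, the chloro-for-hydrogen step is the only one that bears on this change, and no measured pair shows methoxy in place of hydrogen, so the expectation rests on removing chloro alone. Compound 4 is expected to give 8000 nM, between 2500 nM and 25000 nM. That estimate means an expected step of a 3.0-fold lower number from compound 3 to compound 4 (0.48 log units; beyond the scatter).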

Compound 4, concentration for total growth inhibition: 17400 nM
Compound 4: the middle estimate sits 2.2-fold (0.34 log units) below what was measured, within the range that was stated.
By their numbers in this assay, from the lowest: compound 2; then compounds 1, 4 and 3 (each within the scatter of the next).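

In this assay, methoxy in place of chloro gives a 1.4-fold lower number from compound 3 to compound 4 (0.14 log units; within the scatter), so the two groups cannot be told apart at this position on the ring. The earlier rise is therefore not confined to chloro: methoxy in place of hydrogen also gives a 4.3-fold higher number from compound 2 to compound 4 (0.63 log units; beyond the scatter), in the same direction as a 5.9-fold higher number from compound 2 to compound 3 (0.77 log units; beyond the scatter). Among compounds 2, 3 and 4, the compound carrying hydrogen has the lowest number.

From the compounds shown here alone, whether an amine or a carboxylic acid at this position would follow chloro and methoxy or stay with hydrogen remains open. Nothing available here explains these steps.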